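This account rests on a few compounds, and the source may have more. Where it says the series, first, only, none or still open, it means among the compounds named here.

Working notes on the series. All three measured compounds share one core and differ only in the aryl group on the aromatic nitrogen. In a functional assay on PC-3 cells (Homo sapiens) for antiproliferative activity, read by MTT assay, with a stated time of 48 h (a higher number here means a weaker inhibitor, a lower number a stronger inhibitor), compound 1 `COc1cc(/C=C/C(C)=O)ccc1OCc1cn(-c2c(F)cccc2F)nn1` gives 24200 nM. Compound 2 `COc1cc(/C=C/C(C)=O)ccc1OCc1cn(-c2c(Cl)cccc2Cl)nn1` gives 3070 nM in this assay. Compound 3 `COc1cc(/C=C/C(C)=O)ccc1OCc1cn(-c2ccc(C)cc2)nn1` gives 58100 nM in this assay, the highest of the three numbers; compound 1 lies nearest to it, compound 2 furthest. The steps that reach compound 3 are a 2.4-fold higher number from compound 1 to compound 3 (0.38 log units; beyond the scatter) and a 19-fold higher number from compound 2 to compound 3 (1.28 log units; beyond the scatter), and between the two halogenated analogues a 7.9-fold lower number from compound 1 to compound 2 (0.90 log units; beyond the scatter).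

Compound 4 `COc1cc(/C=C/C(C)=O)ccc1OCc1cn(-c2ccccc2O)nn1` carries 2-hydroxyphenyl in place of 4-methylphenyl on an aromatic nitrogen. Going by the values given here, no measured step swaps a 4-methylphenyl for a 2-hydroxyphenyl, so the two steps ending at compound 3 bear only indirectly: both show that leaving 4-methylphenyl for a 2,6-difluorophenyl or a 2,6-dichlorophenyl gives a lower number, by a modest to large amount. A single hydroxyl is a different change, and a cautious expectation is a modest downward step, estimated as a 2.3-fold lower number from compound 3 to compound 4 (0.37 log units; beyond the scatter) in this assay. Compound 4 is therefore expected near 25000 nM, with an estimated range from 8000 nM to 75000 nM.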

Compound 4, half-maximal inhibitory concentration: 59200 nM
Compound 4: middle estimate off by 2.4-fold (0.37 log units), on the low side; the measured number falls inside the stated range.
By their numbers in this assay, from the lowest: compound 2; then compound 1; then compounds 3 and 4 (each within the scatter of the next).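

In this assay the reading of a 1.0-fold higher number from compound 3 to compound 4 (0.01 log units; within the scatter) shows that, on this aromatic nitrogen, 2-hydroxyphenyl and 4-methylphenyl are not told apart, even though the entering group brings a hydrogen-bond donor and a hydrogen-bond acceptor that the leaving group lacks. With a 19-fold higher number from compound 2 to compound 4 (1.29 log units; beyond the scatter) and a 2.4-fold higher number from compound 1 to compound 4 (0.39 log units; beyond the scatter) in addition, 2-hydroxyphenyl stands on the same side of both halogenated analogues as 4-methylphenyl, and compound 2 keeps the lowest number of the four. No measured evidence accounts for these steps.

The compounds shown leave open whether 2-aminophenyl or 4-hydroxyphenyl would read like 2-hydroxyphenyl. They also leave open whether 2-chlorophenyl, with one chlorine only, would stay close to the 2,6-dichlorophenyl of compound 2.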